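Methoxy for fluoro on the shared core

The compounds below may be only part of what the source reports. "The series", "measured", "known", "first", "only" and "open" are said of these compounds alone.

Measured compounds:
compound 1 `CC(C)=CCOc1c(C)c(C)c2c(c1C)CCC(C)(COc1ccc(/C=C3\SC(=O)NC3=O)cc1-c1ccc(F)cc1)O2` 87%
compound 2 `CC(C)=CCOc1c(C)c(C)c2c(c1C)CCC(C)(COc1ccc(/C=C3\SC(=O)NC3=O)cc1F)O2` 95%

The two compounds were measured in a functional assay on MCF7 cells (Homo sapiens), tested at 2.5 uM; a higher number here means a weaker effect of the compound at the concentration tested, a lower number a stronger effect. Going by the values given here, compound 1 gives 87%, and compound 2 gives 95%; the single measured step, a number 8 percentage points higher from compound 1 to compound 2 (within the scatter), is within the scatter, so compound 2 stands at the higher of the two numbers without being distinguishable from compound 1.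

Compound 3 `COc1cc(/C=C2\SC(=O)NC2=O)ccc1OCC1(C)CCc2c(C)c(OCC=C(C)C)c(C)c(C)c2O1` differs from compound 2 by methoxy in place of fluoro on an aromatic carbon. Among the compounds with values here, no measured step concerns a methoxy group, and the one step available, fluoro in place of 4-fluorophenyl, stayed within the scatter. With nothing pointing in either direction, compound 3 is expected to sit near compound 2 in this assay, a step of a number 5 percentage points lower from compound 2 to compound 3 (within the scatter) that does not go beyond the scatter. The estimate for compound 3 is 90%, with a range from 75% to 105%.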

Compound 3, a percentage reported as activity, at one concentration (the size of the read-out at that concentration, not a potency): 95%
Compound 3: the middle estimate sits 5 percentage points below what was measured; measured number inside the range.
By their numbers in this assay, from the lowest: compounds 1, 2 and 3 (each within the scatter of the next).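

In this assay, replacing fluoro with methoxy on this aromatic carbon, ortho to a large group, brings in a hydrogen-bond acceptor and gives no change at the digits printed from compound 2 to compound 3 (within the scatter). Methoxy in place of 4-fluorophenyl gives a number 8 percentage points higher from compound 1 to compound 3 (within the scatter), so a third substituent at this position, and the first with an oxygen attached to the ring, also gives a number that cannot be told apart from the others. No evidence on these groups is available to explain the result.

The compounds shown leave open whether an amine or a carboxylic acid at this position would give a number beyond the scatter of these three. They also leave open whether the three would remain indistinguishable at another concentration.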